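Urea-to-benzamide change on the shared pyrazole-bearing core

This account rests on a few compounds, and the source may have more. Where it says the series, first, only, none or still open, it means among the compounds named here.

Measured compounds:
compound 1 `COc1cc(-c2nn(-c3cccc(NC(=O)Nc4ccc(Cl)c(Cl)c4)c3)cc2-c2ccncc2)ccc1Cl` gives 937 nM in a functional assay on COLO 205 cells (Homo sapiens) for inhibition, read by sulforhodamine B assay, with a stated time of 48 h; on this read-out lower numbers stand for stronger inhibition of growth and higher numbers for weaker inhibition of growth;
compound 2 `COc1cc(-c2nn(-c3cccc(NC(=O)c4ccc(Cl)c(C(F)(F)F)c4)c3)cc2-c2ccncc2)ccc1Cl` gives 6140 nM in this assay;
compound 3 `COc1cc(-c2nn(-c3cccc(NC(=O)Nc4ccc(Cl)c(C(F)(F)F)c4)c3)cc2-c2ccncc2)ccc1Cl` gives 711 nM in this assay.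

Compound 3 has the lowest number of the three. Its nearest neighbour is compound 1, the step of a 1.3-fold lower number from compound 1 to compound 3 (0.12 log units; within the scatter) being within the scatter, so the two cannot be ordered. Compound 2 stands furthest away, as the step of an 8.6-fold lower number from compound 2 to compound 3 (0.94 log units; beyond the scatter) shows.

Compound 4 `COc1cc(-c2nn(-c3cccc(NC(=O)c4ccccc4)c3)cc2-c2ccncc2)ccc1Cl` has not been measured. It differs from compound 3 by phenyl in place of (4-chloro-3-(trifluoromethyl)phenyl)amino on a carbonyl carbon. Going by the values given here, two measured steps bear on this. The step of an 8.6-fold lower number from compound 2 to compound 3 (0.94 log units; beyond the scatter) shows that the aryl amide of compound 2 gives a much higher number than the aryl urea of compound 3, and the step of a 6.6-fold higher number from compound 1 to compound 2 (0.82 log units; beyond the scatter) points the same way. Among the compounds with values here, compound 4 is an amide like compound 2 but also lacks the chloro and trifluoromethyl groups, for which no step is measured. Compound 4 is therefore expected to give a step of a 21-fold higher number from compound 3 to compound 4 (1.32 log units; beyond the scatter), well beyond the scatter and upward. For compound 4 the estimate in this assay is 15000 nM, with a range from 4000 nM to 50000 nM.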

Compound 4, concentration for 50% growth inhibition: 522 nM
Estimate against measurement, compound 4: 29-fold (1.46 log units) above; the whole stated range lies above it.
By their numbers in this assay, from the lowest: compounds 4, 3 and 1 (each within the scatter of the next); then compound 2.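

In this assay, the plain phenyl amide of compound 4 cannot be ordered against either urea: a 1.4-fold lower number from compound 3 to compound 4 (0.13 log units; within the scatter) and a 1.8-fold lower number from compound 1 to compound 4 (0.25 log units; within the scatter) both lie within the scatter. Going by these compounds alone, the amide link on this carbonyl carbon therefore does not by itself go with a high number, as the earlier compounds had suggested. Among the two amides, the high number goes with the 4-chloro-3-(trifluoromethyl)phenyl group, with a 12-fold lower number from compound 2 to compound 4 (1.07 log units; beyond the scatter) beyond the scatter, and the urea nitrogen is not required for a number in the range of the ureas.

As far as these compounds go, it remains open whether the chloro or the trifluoromethyl group accounts for this gap, how a urea carrying an unsubstituted phenyl would compare, and what an amine or a carboxylic acid on this phenyl ring would do. Nothing available explains why the substituted amide stands apart.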